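This account rests on a few compounds, and the source may have more. Where it says the series, first, only, none or still open, it means among the compounds named here.

Measured in an ADME assay on L6 cells (Rattus norvegicus) for cytotoxicity, read by resazurin assay, with a stated time of 72 h; on this read-out lower numbers stand for stronger inhibition and higher numbers for weaker inhibition:
- compound 1 `CC(C)(C)c1ccc(C(=O)NC(=O)c2ccccc2O)cc1`: 2.3 ug/mL
- compound 2 `CCCCOc1ccc(C(=O)NC(=O)c2ccccc2O)cc1`: 13 ug/mL

Of these two, compound 2 stands higher, at 13 ug/mL. Compound 3 `O=C(NC(=O)c1ccccc1O)c1ccc(OCc2ccccc2)cc1` differs from it as follows: phenyl in place of propyl on a saturated chain carbon bound to an oxygen on an aromatic ring. Phenyl takes the place of propyl on a saturated chain carbon bound to an oxygen on an aromatic ring, turning butoxy into benzyloxy. For the measured compounds named here, only one measured step bears on this, a 5.7-fold higher number from compound 1 to compound 2 (0.75 log units; beyond the scatter), and it was modest and involved a different change. Going by the values given here, with no measured step to fix the direction, a small shift toward lower numbers is tentatively expected: a 1.4-fold lower number from compound 2 to compound 3 (0.16 log units; within the scatter). For compound 3 the estimated value is 9 ug/mL, with an expected range of 3 ug/mL to 25 ug/mL.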

Compound 3, half-maximal inhibitory concentration: 64 ug/mL
The estimate for compound 3 lay 7.1-fold (0.85 log units) below the measured number; measured number above the stated range.
By their numbers in this assay, from the lowest: compound 1; then compound 2; then compound 3.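

In this assay, phenyl in place of propyl on a saturated chain carbon bound to an oxygen on an aromatic ring gives a 4.9-fold higher number from compound 2 to compound 3 (0.69 log units; beyond the scatter), so this site responds to the change from butoxy to benzyloxy. Measured against tert-butyl, benzyloxy gives a 28-fold higher number from compound 1 to compound 3 (1.44 log units; beyond the scatter), and compound 3 shows the weakest inhibition of the three. Nothing available explains this shift. Still open, on these data alone, is whether cyclohexyl in place of phenyl would give a number nearer that of compound 2 or compound 3, and how a longer chain such as hexyloxy would compare with butoxy.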